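This account rests on a few compounds, and the source may have more. Where it says the series, first, only, none or still open, it means among the compounds named here.

Measured so far in a functional assay on corpus cavernosum (Rattus norvegicus) for activation; a higher number here means a larger maximal response, a lower number a smaller maximal response:

- compound 1, `CCCCOc1ccccc1-c1nc2c(cnn2-c2ccccc2)c(=O)[nH]1`: 170%
- compound 2, `CCCCOc1ccccc1-c1nc2c(cnn2-c2ccc(Br)cc2)c(=O)[nH]1`: 160%
- compound 3, `Nc1ccccc1NCc1nc2c(cnn2-c2ccccc2)c(=O)[nH]1`: 113%

Compound 1 and compound 2 share one core and differ at a single place, (bromo in place of hydrogen on an aromatic carbon). The step of a number 10 percentage points lower from compound 1 to compound 2 (within the scatter) is small; the two maximal responses cannot be told apart within the usual scatter of this assay. Compound 3 carries a different core; how the cores of compound 3 and compound 1 differ is not broken down here. In this assay compound 3 gives the lowest of the three numbers, beyond the scatter from both compound 2 and compound 1.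

Compound 4, `Nc1ccccc1NCc1nc2c(cnn2-c2ccc(Br)cc2)c(=O)[nH]1`, is not yet measured. It differs from compound 3 in one place, (bromo in place of hydrogen on an aromatic carbon). The place description reads the same, word for word, as for the pair compound 1 and compound 2, so this is the same change made on the other core. For the measured compounds named here, the only information on what this change does to the maximal response is the step from compound 1 to compound 2, which is flat. On that basis the expected step is a number 8 percentage points lower from compound 3 to compound 4 (within the scatter), essentially no change, because a number 10 percentage points lower from compound 1 to compound 2 (within the scatter) showed none. As far as these compounds go, whether the same holds on the core of compound 3 is untested; a single precedent is thin ground. The estimate for compound 4 in this assay is 105%, with a range from 85% to 125%.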

Compound 4, largest response reached (Emax), in percent of the reference or control that the assay uses: 148%
Compound 4: the middle estimate sits 43 percentage points below what was measured; measured number above the stated range.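

In this assay, phenyl to 4-bromophenyl does not carry over from one core to the other as a fixed increment: the same change on two cores in this assay, a number 10 percentage points lower (within the scatter) from compound 1 to compound 2 and a number 35 percentage points higher (beyond the scatter) from compound 3 to compound 4, 45 percentage points apart, beyond the scatter of two such steps. On the core of compound 3, the change gives a number 35 percentage points higher from compound 3 to compound 4 (beyond the scatter), whereas on the core of compound 1 the two maximal responses cannot be told apart. For the compounds shown here, this shows that, for these two pairs, the outcome of the same change depends on the core, but it does not show which structural difference between the cores is responsible or how the change would behave on a third core, and each core contributes only one pair in a single assay.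

The compounds shown leave open whether chloro or methoxy, placed on the same six-membered aromatic ring para to a large group, would follow the pattern of bromo on each core. Also open, as far as these compounds go, is whether a carboxylic acid or a nitrile at that place would raise the maximal response on the core of compound 3 or leave it flat, as bromo does on the core of compound 1.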